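Cyclopentyl for cyclopropylmethyl on the shared core

The compounds below may be only part of what the source reports. "The series", "measured", "known", "first", "only" and "open" are said of these compounds alone.

Within the data shown here, in a functional assay on HCT-116 cells (Homo sapiens) for cytotoxicity, read by MTT assay, with a stated time of 48 h (on this read-out lower numbers stand for stronger inhibition of growth and higher numbers for weaker inhibition of growth), compound 1 `FC(F)(F)c1nc2cc(Cl)c(Cl)cc2n1CC1CC1` gives 61300 nM, the higher of the two numbers so far. Compound 2 `Nc1cccc(Cn2c(C(F)(F)F)nc3cc(Cl)c(Cl)cc32)c1` gives 22600 nM. Compound 3 `FC(F)(F)c1nc2cc(Cl)c(Cl)cc2n1C1CCCC1` carries cyclopentyl in place of cyclopropylmethyl on an aromatic nitrogen. Among the measured compounds shown here, the only measured step, a 2.7-fold lower number from compound 1 to compound 2 (0.43 log units; beyond the scatter), is modest and brings in a 3-aminophenyl group absent from compound 3, so it bears only loosely. On these data alone, no step beyond the scatter is expected in this assay, and the direction remains open. The estimated step is a 1.4-fold lower number from compound 1 to compound 3 (0.13 log units; within the scatter). Compound 3 is expected at 45000 nM, with an estimated range from 18000 nM to 100000 nM.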

Compound 3, concentration for 50% growth inhibition: 22000 nM
Compound 3: middle estimate off by 2.0-fold (0.31 log units), on the high side; measured number inside the range.
By their numbers in this assay, from the lowest: compounds 3 and 2 (each within the scatter of the next); then compound 1.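

At this aromatic nitrogen, a purely carbon change with no hydrogen-bond donor or acceptor is enough to give a step beyond the scatter in this assay: a 2.8-fold lower number from compound 1 to compound 3 (0.45 log units; beyond the scatter). The 3-aminophenyl group is therefore not the only route to this level, since compound 3 and compound 2 lie within the scatter of each other. Nothing measured here accounts for the step.

On these data alone, whether a cyclohexyl ring, a longer alkyl chain or an amine at this nitrogen would lower the number further stays open.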